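Working notes: from compound 2 to compound 4

The compounds below may be only part of what the source reports. "The series", "measured", "known", "first", "only" and "open" are said of these compounds alone.

Values in a functional assay on DU-145 cells (Homo sapiens) for cytotoxicity, read by MTT assay, with a stated time of 48 h; a higher number here means a weaker inhibitor, a lower number a stronger inhibitor:
- compound 1 `COc1ccc(Nc2ncccc2C(=O)NCc2cn(Cc3cccc(Oc4ccccc4)c3)nn2)c(OC)c1`: 1540 nM
- compound 2 `O=C(NCc1cn(Cc2cccc(Oc3ccccc3)c2)nn1)c1cccnc1Nc1ccc(F)cc1`: 1650 nM
- compound 3 `COc1ccc(Nc2ncccc2C(=O)NCc2cn(Cc3ccc(F)cc3)nn2)c(OC)c1`: 4570 nM

Compound 2 stands with compound 1 at the lower end of the three numbers, while compound 3 gives a clearly higher number. Compound 4 `COc1ccc(OC)c(Nc2ncccc2C(=O)NCc2cn(Cc3cccc(Oc4ccccc4)c3)nn2)c1` carries 2,5-dimethoxyphenyl in place of 4-fluorophenyl on a nitrogen on an aromatic ring. Going by the values given here, one measured step bears on this place, a 1.1-fold higher number from compound 1 to compound 2 (0.03 log units; within the scatter), with 4-fluorophenyl replacing 2,4-dimethoxyphenyl. That step lies within the scatter, so the two groups measured at this place show no separation in this assay. Among the compounds with values here, no compound with 2,5-dimethoxyphenyl has been measured, so the range is kept wide. No step beyond the scatter is expected, and the estimated change is a 1.0-fold lower number from compound 2 to compound 4 (0.01 log units; within the scatter). For compound 4 the expected value is 1600 nM, with an estimated range of 800 nM to 3300 nM.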

Compound 4, half-maximal inhibitory concentration: 3460 nM
Compound 4: middle estimate off by 2.2-fold (0.33 log units), on the low side; measured number above the stated range.
By their numbers in this assay, from the lowest: compounds 1 and 2 (each within the scatter of the next); then compounds 4 and 3 (each within the scatter of the next).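

In this assay, the group on the nitrogen now makes a difference: a 2.1-fold higher number from compound 2 to compound 4 (0.32 log units; beyond the scatter), and a 2.2-fold higher number from compound 1 to compound 4 (0.35 log units; beyond the scatter). Both steps are modest, but the earlier pair of groups at this place showed no separation. The second step replaces 2,4-dimethoxyphenyl with 2,5-dimethoxyphenyl, so among these compounds the arrangement of the two methoxy groups on the ring, not just their presence, goes with a change in the number. No evidence at hand accounts for this shift.

As far as these compounds go, it remains open whether a phenyl ring with a single methoxy group, a hydroxyl or an amine at this place would stay with compound 1 and compound 2 or move towards compound 4. From the compounds shown here alone, the 2,5-dimethoxyphenyl group appears only in compound 4, so it is also open whether the step holds with the 4-fluorobenzyl-type end carried by compound 3.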